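Moving one hydroxy group: what compound 3 may do

The compounds below may be only part of what the source reports. "The series", "measured", "known", "first", "only" and "open" are said of these compounds alone.

In a functional assay on KM12 cells (Homo sapiens) for inhibition, read by sulforhodamine B assay, with a stated time of 48 h (on this read-out higher numbers stand for weaker inhibition of growth and lower numbers for stronger inhibition of growth), compound 1 `O=C(Cc1csc2nc(-c3ccc(Br)cc3)cn12)N/N=C/c1ccccc1` gives > 100000 nM, and this value is a limit of the assay, not a number. For the measured compounds named here, compound 2 `O=C(Cc1csc2nc(-c3ccc(Br)cc3)cn12)N/N=C/c1ccccc1O` gives 17000 nM, which is the only true number so far. Between these two compounds lies one measured step, an at least 5.8-fold lower number from compound 1 to compound 2 (0.76 log units; beyond the scatter), which came with hydroxy in place of hydrogen on an aromatic carbon. As far as these compounds go, one end of that step rests on (the limit of > 100000 nM in this assay, at which 1 of the 2 values shown sits), so its full size stays open.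

Compound 3 `O=C(Cc1csc2nc(-c3ccc(Br)cc3)cn12)N/N=C/c1ccc(O)cc1` has the same atoms as compound 2, joined differently: 4-hydroxyphenyl in place of 2-hydroxyphenyl on a carbon with a double bond to nitrogen. In words, 4-hydroxyphenyl stands in place of 2-hydroxyphenyl on a carbon with a double bond to nitrogen. Going by the values given here, no measured step moves the hydroxy group, but compound 3 keeps the group whose arrival gave an at least 5.8-fold lower number from compound 1 to compound 2 (0.76 log units; beyond the scatter). The expected change in this assay is therefore none beyond the scatter, with an estimated step of a 1.5-fold higher number from compound 2 to compound 3 (0.17 log units; within the scatter). For compound 3 the estimate is 25000 nM, with an expected range of 8000 nM to 80000 nM.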

Compound 3, concentration for total growth inhibition: 75900 nM
Estimate against measurement, compound 3: 3.0-fold (0.48 log units) below; measured number inside the range.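

In this assay, for the compounds shown here, the earlier step showed only that adding a hydroxy group could matter, whereas this result shows that its place matters too: with the same atoms joined differently, 4-hydroxyphenyl in place of 2-hydroxyphenyl on a carbon with a double bond to nitrogen gives a 4.5-fold higher number from compound 2 to compound 3 (0.65 log units; beyond the scatter). A hydroxy group on this ring is therefore not enough on its own to secure the clear gain seen with 2-hydroxyphenyl, for the step to 4-hydroxyphenyl from the compound without a hydroxy group is an at least 1.3-fold lower number from compound 1 to compound 3 (0.11 log units; that floor lies within the scatter). That step gives only a floor whose size stays open, and any real gain may be larger, because the value of compound 1 is a limit of the assay and not a number: the limit of > 100000 nM in this assay, at which 1 of the 3 values shown sits.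

The compounds shown leave open whether a methoxy group or an amine in place of the hydroxy group of 2-hydroxyphenyl would keep the lower number of compound 2. They also leave open whether compound 2 would still give the lower number than compound 3 if a chlorine atom replaced the bromine atom on the shared core.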